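This account rests on a few compounds, and the source may have more. Where it says the series, first, only, none or still open, it means among the compounds named here.

Measured in an assay on RBL-1 cells for inhibition of Polyunsaturated fatty acid 5-lipoxygenase (Rattus norvegicus); on this read-out lower numbers stand for stronger inhibition and higher numbers for weaker inhibition:

- compound 1 `CCc1cccc(N2CCNC(=O)N2)c1`, 13000 nM
- compound 2 `Cc1cccc(N2CC(C)NC(=O)N2)n1`, 3800 nM
- compound 3 `O=C1NCCN(c2cccc(Cl)n2)N1`, 5600 nM

Compound 1 stands at the highest number of the three. Its nearest neighbour is compound 3, with a lower number that lies beyond the scatter; compound 2 lies lower still, also beyond the scatter. Within the data shown here, no two of the measured compounds differ in one place only, so no single-change step is known in this assay.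

Compound 4 `O=C1NCCN(c2cccc(-c3ccccn3)c2)N1` differs from compound 1 by pyridin-2-yl in place of ethyl on an aromatic carbon. Among the measured compounds shown here, nothing among the measured compounds shows what such a change does. For compound 4 the expected step is a 2.2-fold lower number from compound 1 to compound 4 (0.34 log units; beyond the scatter), towards a lower number, of modest size and possibly not beyond the scatter. Compound 4 is estimated at 6000 nM, in a range from 1500 nM to 25000 nM.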

Compound 4, half-maximal inhibitory concentration: 30000 nM
The estimate for compound 4 lay 5.0-fold (0.70 log units) below the measured number, outside the stated range (above it).
By their numbers in this assay, from the lowest: compounds 2 and 3 (each within the scatter of the next); then compound 1; then compound 4.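

In this assay pyridin-2-yl in place of ethyl on the aromatic carbon gives a 2.3-fold higher number from compound 1 to compound 4 (0.36 log units; beyond the scatter) and so brings no gain in inhibition at this position. The step is modest, so this position tolerates the added aromatic ring with only a limited loss. No measurement on hand bears on why the number rises.

Going by these compounds, whether phenyl would behave like pyridin-2-yl here remains open, which leaves the role of the ring nitrogen unsettled. Also open, on these data alone, is how a methoxy group, an amine or a carboxylic acid in place of ethyl would shift the number.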